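Taking the nitro group off compound 3

A few compounds are considered here, and "the series" means these few. Any claim that something is new, unique, unknown or untested is made for them only; others in the source may bear on it.

Of the compounds shown here, three on a shared core have been measured for cytotoxicity. Compound 1 `Cc1nc2c3ccccc3ccc2c2nc3c(ccc4ccccc43)c(-c3cccc([N+](=O)[O-])c3)c12` gives 25500 nM in a functional assay on AGS cells (Homo sapiens) for cytotoxicity, read by MTT assay, with a stated time of 48 h; a lower number here means a stronger inhibitor, a higher number a weaker inhibitor. Compound 2 `COc1ccc(-c2c3ccc4ccccc4c3nc3c2c(C)nc2c4ccccc4ccc32)cc1` gives 66400 nM in this assay, and the change of substituent on the aromatic carbon gives a 2.6-fold higher number from compound 1 to compound 2 (0.42 log units; beyond the scatter). Compound 3 `Cc1nc2c3ccccc3ccc2c2nc3c(ccc4ccccc43)c(-c3cc([N+](=O)[O-])ccc3N)c12` gives 17800 nM in this assay, the lowest of the three numbers; its neighbour compound 1 sits within the scatter, as a 1.4-fold lower number from compound 1 to compound 3 (0.16 log units; within the scatter) shows, while compound 2 lies further off, with a 3.7-fold lower number from compound 2 to compound 3 (0.57 log units; beyond the scatter).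

Compound 4 `Cc1nc2c3ccccc3ccc2c2nc3c(ccc4ccccc43)c(-c3ccccc3N)c12` is the next step from compound 3: hydrogen in place of nitro on an aromatic carbon. Within the data shown here, no measured step removes a nitro group, so the evidence is indirect. Among the measured compounds shown here, the only step that touches the same ring without exchanging the whole substituent, the amino addition, was within the scatter in this assay, and even the full exchange of the substituent between compound 1 and compound 2 moved the number only modestly. The expected step of a 1.2-fold higher number from compound 3 to compound 4 (0.09 log units; within the scatter) is therefore small, with a slight lean toward a higher number but not clearly beyond the scatter. Compound 4 is expected to give about 22000 nM in this assay, within a range from 9000 nM to 55000 nM.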

Compound 4, half-maximal inhibitory concentration: 12100 nM
Beside the measured number, compound 4's estimate is 1.8-fold (0.26 log units) above it; measured number inside the range.
By their numbers in this assay, from the lowest: compounds 4, 3 and 1 (each within the scatter of the next, the first and the last beyond it); then compound 2.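

In this assay, hydrogen in place of nitro, on the carbon para to the amino group and meta to a large group, gives a 1.5-fold lower number from compound 3 to compound 4 (0.17 log units; within the scatter), so the nitro group at this place is not needed to keep the number at the level seen with the 2-amino-5-nitrophenyl substituent. Among these compounds, its removal does, however, bring out a difference the earlier compounds did not show: 2-aminophenyl in place of 3-nitrophenyl gives a 2.1-fold lower number from compound 1 to compound 4 (0.32 log units; beyond the scatter), beyond the scatter, whereas the earlier step from the same compound to the amino-bearing, nitro-carrying compound 3 stayed within it. Against the 4-methoxyphenyl substituent, 2-aminophenyl gives a 5.5-fold lower number from compound 2 to compound 4 (0.74 log units; beyond the scatter), the largest step in the series and also beyond the scatter. Nothing available here accounts for these steps.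

The compounds shown leave open what a group other than nitro, such as a carboxylic acid or a dimethylamino group, would give at this same place on the 2-aminophenyl ring. They also leave open how much the amino group itself contributes, as the series holds no plain phenyl on the shared core to set against compound 4.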